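The source may report more compounds than this note shows. Statements on the series, on what has been measured and on what is new or still open speak of the compounds shown alone.

For the measured compounds named here, compound 3 `COc1ncnc2c1c(I)cn2[C@@H]1O[C@H](CO)[C@@H](O)[C@H]1O` is the only compound in this set that gives an actual number in an ADME assay on BJ cells (Homo sapiens), read by MTT assay, with a stated time of 72 h; on this read-out lower numbers stand for stronger inhibition and higher numbers for weaker inhibition: compound 3 returns 91000 nM. The two other results are limits of the assay rather than numbers. For compound 1 `Nc1nc(N)c2c(-c3ccsc3)cn([C@@H]3O[C@H](CO)[C@@H](O)[C@H]3O)c2n1` this assay reports only the limit > 100000 nM. For compound 2 `Nc1nc(N)c2c(-c3cc4ccccc4o3)cn([C@@H]3O[C@H](CO)[C@@H](O)[C@H]3O)c2n1` this assay likewise reports only the limit > 100000 nM. Going by the values given here, the single step between measured compounds, a step that the two limits leave unreadable from compound 1 to compound 2, cannot be sized because both of its ends sit at the limit of > 100000 nM in this assay, at which 2 of the 3 values shown sit.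

Compound 4 `COc1ncnc2c1c(-c1cccs1)cn2[C@@H]1O[C@H](CO)[C@@H](O)[C@H]1O` differs from compound 3 in one place: thiophen-2-yl in place of iodo on an aromatic carbon. No measured step follows this exchange of iodo for an aromatic ring on the same core, and the one step that is shown is unreadable, so nothing here fixes the size or direction of the change. What the data do show is that the two compounds carrying an aromatic ring on an aromatic carbon, compound 1 and compound 2, both sit at the limit, and that compound 3 itself already lies close to it. Compound 4 is therefore expected to stay in the same region, with an expected step of a 1.1-fold higher number from compound 3 to compound 4 (0.04 log units; within the scatter) that would not stand out beyond the scatter. Compound 4 is estimated at 100000 nM, within a range from 30000 nM to 300000 nM.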

Compound 4, half-maximal inhibitory concentration: 62800 nM
Beside the measured number, compound 4's estimate is 1.6-fold (0.20 log units) above it, and the stated range covers the measured number.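

In this assay, for the compounds shown here, the exchange of iodo for thiophen-2-yl gives the first step in this set with a real number at both ends: a 1.4-fold lower number from compound 3 to compound 4 (0.16 log units; within the scatter). On the shared core, therefore, replacing a single iodine atom with a five-membered aromatic ring of 5 heavy atoms on this aromatic carbon, two ring bonds from the ring nitrogen, leaves the read-out within the usual scatter, and compound 4, with that ring in place, still gives a readable number. The results for compound 1 and compound 2 remain limits of the assay rather than numbers, and the step between them cannot be read: the limit of > 100000 nM in this assay, at which 2 of the 4 values shown sit.

The compounds shown leave open whether a different kind of group on this aromatic carbon, such as an amine or a carboxylic acid, would give a step beyond the scatter. They also leave open whether the same exchange of iodo for thiophen-2-yl would give a readable step on the core of compound 1, where the only results shown so far are limits.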